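This account rests on a few compounds, and the source may have more. Where it says the series, first, only, none or still open, it means among the compounds named here.

Measured in a functional assay on MGC-803 cells (Homo sapiens) for cytotoxicity, read by MTT assay, with a stated time of 48 h; on this read-out lower numbers stand for stronger inhibition and higher numbers for weaker inhibition:

- compound 1 `CCN(CC)CC(=O)N1N=C(C)CC1c1ccccc1O`: 39800 nM
- compound 2 `CCN(CC)CC(=O)N1N=C(C)CC1c1ccccc1OC(C)=O`: 29500 nM

Only these two compounds have been measured, and compound 2, at 29500 nM, lies within the scatter of compound 1, so the pair cannot be ranked. Compound 2 therefore stands at the same level as the only other point available. The next compound, compound 3 `CC(=O)Oc1ccccc1C1CC(C)=NN1C(=O)CN(C(C)C)C(C)C`, keeps the acetyl group of compound 2 and changes the amine: diisopropylamino in place of diethylamino on a saturated chain carbon bound to a carbonyl carbon.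

Going by the values given here, the single measured step, a 1.3-fold lower number from compound 1 to compound 2 (0.13 log units; within the scatter), bears on this only indirectly. It concerns acetyl in place of hydrogen on an oxygen on an aromatic ring, and it stays within the scatter. Among the compounds with values here, no measured pair varies the amine, so the data give no direction for this change, and no shift beyond the scatter is expected in this assay. The expected change is a 1.1-fold lower number from compound 2 to compound 3 (0.02 log units; within the scatter). For compound 3 the estimated value is 28000 nM, with an expected range from 12000 nM to 65000 nM.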

Compound 3, half-maximal inhibitory concentration: 20100 nM
Compound 3: middle estimate off by 1.4-fold (0.14 log units), on the high side, within the range that was stated.
By their numbers in this assay, from the lowest: compounds 3, 2 and 1 (each within the scatter of the next).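

Going by these compounds alone, this is the first measured change at this position, a saturated chain carbon bound to a carbonyl carbon: in this assay, with the acetyl group held constant, diisopropylamino in place of diethylamino gives a 1.5-fold lower number from compound 2 to compound 3 (0.17 log units; within the scatter), so the step stays within the scatter. The position thus accepts diisopropylamino, with 7 heavy atoms against 5 for diethylamino, without a change in the read-out that can be told apart from repeated measurement, and a single pair of alkyl amines sets no trend for this position. Nothing on hand gives a reason for this result.

As far as these compounds go, whether a ring amine such as piperidine or morpholine, or a plain dimethylamino group, would move the number beyond the scatter remains open, as does the effect of a longer chain between the carbonyl and the amine nitrogen. Within the data shown here, also open is whether diisopropylamino would behave in the same way with the free hydroxyl of compound 1 in place of the acetyl ester, as no single-place pair yet tests the amine change there.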